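The source may report more compounds than this note shows. Statements on the series, on what has been measured and on what is new or still open speak of the compounds shown alone.

In an ADME assay on a cell-free system (plasma, Homo sapiens) for metabolic stability, read by LC-MS (on this read-out lower numbers stand for a shorter-lived compound and higher numbers for a longer-lived compound), three compounds have been measured so far: compound 1 (`COc1cc(/C=C/C(=O)O[C@H]2CC[C@@H](N(C)CCCCOC(=O)c3cc(OC)c(OC)c(OC)c3)CC2)cc(OC)c1OC`), compound 2 (`COc1cc(/C=C/C(=O)O[C@H]2CC[C@@H](N(C)CCCCCOC(=O)c3cc(OC)c(OC)c(OC)c3)CC2)cc(OC)c1OC`) and compound 3 (`COc1cc(/C=C/C(=O)OCCCCCN(C)[C@H]2CC[C@@H](OC(=O)c3cc(OC)c(OC)c(OC)c3)CC2)cc(OC)c1OC`). Compound 1 gives >= 4 h, which is a limit of the assay and not a number. Compound 2 gives >= 4 h, which is again a limit. Compound 3 gives >= 4 h, which is also a limit, so it has no exact half-life on record. The three cannot be ranked, and the whole set stands at one point: the limit of >= 4 h in this assay, at which 3 of the 3 values shown sit.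

The next compound to be measured is compound 4 (`COc1cc(/C=C/C(=O)OCCCCCN(C)[C@H]2CC[C@H](OC(=O)c3cc(OC)c(OC)c(OC)c3)CC2)cc(OC)c1OC`). The difference from compound 3 is this: the two compounds have the same atoms and bonds and differ only in configuration as drawn: 2 of 3 stereo elements differ; a stereocentre at a saturated ring carbon is drawn s in compound 3 and r in compound 4; a stereocentre at a saturated ring carbon is drawn s in compound 3 and r in compound 4. The two compounds have the same atoms and bonds and differ only in configuration as drawn, at two saturated ring carbons. Among the compounds with values here, no measured pair shows what such a change does in this assay. The expectation therefore rests on the limit of compound 3, given as >= 4 h, and on the absence of any change in atoms or bonds. The expected move, a number no higher from compound 3 to compound 4 (the limit leaves the size open), is estimated to lie within the usual scatter, and compound 4 may well be reported only as a limit too. For compound 4 the estimated half-life is 4 h, with an expected range from 2 h to 8 h.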

Compound 4, half-life: >= 4 h
Compound 4 was reported as a limit (the forecaster's own chance of this, stated with the estimate: 70%); the middle value lies on the limit itself.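

Compound 3 and compound 4 are both reported only as limits in this assay, so no step can be read between them. The compounds shown leave open whether the configuration at the two saturated ring carbons alters the half-life at all, and the whole set stands at one point: the limit of >= 4 h in this assay, at which 4 of the 4 values shown sit.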